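A Bromo-to-Ethylsulfanyl Swap on an Acylguanidine Core

The source may report more compounds than this note shows. Statements on the series, on what has been measured and on what is new or still open speak of the compounds shown alone.

Three acylguanidines with a methylsulfonyl group on the shared core have been measured in a functional assay for inhibition of sodium/hydrogen exchanger (Oryctolagus cuniculus); on this read-out lower numbers stand for stronger inhibition and higher numbers for weaker inhibition. Compound 1, `Cc1cc(Br)c(S(C)(=O)=O)cc1C(=O)N=C(N)N`, gives 12 nM and stands lowest of the three numbers. Compound 2, `CCc1cc(Cl)c(S(C)(=O)=O)cc1C(=O)N=C(N)N`, gives 63 nM, and compound 3, `Cc1c(C(=O)N=C(N)N)cc(S(C)(=O)=O)c(Cl)c1C`, gives 58 nM; both lie beyond the scatter above compound 1, so compound 1 is the most potent of the three on this read-out. No two of the measured compounds differ in only one place, so no single-point step can be read from them.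

Compound 4, `CCSc1cc(C)c(C(=O)N=C(N)N)cc1S(C)(=O)=O`, has not been measured. Compared with compound 1 the change is ethylsulfanyl in place of bromo on an aromatic carbon, on an aromatic carbon ortho to a methylsulfonyl group. Going by the values given here, nothing among the measured compounds tests a change at this carbon, so the size and direction of the step are open. The nearest guide is that compound 1 sits at 12 nM, and a modest move toward weaker inhibition, still near the scatter, is what is expected for the step of a 2.1-fold higher number from compound 1 to compound 4 (0.32 log units; beyond the scatter). Compound 4 is therefore estimated at 25 nM, with a range from 6 nM to 100 nM.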

Compound 4, half-maximal inhibitory concentration: 5.9 nM
Compound 4: middle estimate off by 4.2-fold (0.63 log units), on the high side, outside the stated range (below it).
By their numbers in this assay, from the lowest: compound 4; then compound 1; then compounds 3 and 2 (each within the scatter of the next).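

Ethylsulfanyl in place of bromo gives the first comparison on this core that differs in only one place, and in this assay the swap produces a 2.0-fold lower number from compound 1 to compound 4 (0.31 log units; beyond the scatter) on an aromatic carbon ortho to a methylsulfonyl group. Going by these compounds alone, this carbon therefore tolerates a group of 3 heavy atoms in place of bromo, a group of 1 heavy atom, and inhibition becomes stronger rather than weaker, a direction that the earlier compounds could not reveal because none of them tested a change here. Nothing measured here accounts for the direction or size of this step.

The compounds shown do not tell whether a shorter methylsulfanyl group, an ethoxy group with oxygen in place of the sulfur, or a longer propylsulfanyl chain would keep, enlarge or reverse this step at the same carbon. Nor do they show whether ethylsulfanyl in place of chloro would give a step of similar size and direction on the cores of compound 2 and compound 3.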